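This account rests on a few compounds, and the source may have more. Where it says the series, first, only, none or still open, it means among the compounds named here.

Working notes on the series. The core of compound 1 `N/C(=N\NC(=S)N1CCOCC1)c1ccccn1` carries a morpholine thiocarbonyl; in a functional assay on MCF7 cells (Homo sapiens) for cytotoxicity, read by MTT assay, with a stated time of 72 h, tested at 3 uM (on this read-out higher numbers stand for more inhibition of growth at the one concentration tested and lower numbers for less inhibition of growth), compound 1 gives 44.5%. Compound 3 `Cc1cccc(/C(N)=N/NC(=S)N2CCOCC2)n1` gives 21.6%; the change from compound 3 to compound 1, (hydrogen in place of methyl on an aromatic carbon), is a step of a number 22.9 percentage points higher from compound 3 to compound 1 (beyond the scatter). Compound 2 `Cc1ccnc(/C(N)=N/NC(=S)N2CCN(c3ccccn3)CC2)c1` sits on a different core, and the difference between the two cores is not broken down here; in this assay compound 2 gives 32.8%. Compound 4 `N/C(=N\NC(=S)N1CCN(c2ccccn2)CC1)c1ccccn1` is not yet measured. It differs from compound 2 by hydrogen in place of methyl on an aromatic carbon, the same kind of change as from compound 3 to compound 1, though not the same: there the place was next to the ring nitrogen, here it is opposite the ring nitrogen. Given the step of a number 22.9 percentage points higher from compound 3 to compound 1 (beyond the scatter), a gain is expected from compound 2 to compound 4, estimated as a number 10.2 percentage points higher from compound 2 to compound 4 (beyond the scatter), set smaller than that step to allow for the different place. Compound 4 is thus estimated at 43%, between 25% and 60%.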

Compound 4, percent growth inhibition at one concentration: 37.2%
Beside the measured number, compound 4's estimate is 5.8 percentage points above it; measured number inside the range.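

In this assay, hydrogen in place of methyl gives a number 4.4 percentage points higher from compound 2 to compound 4 (within the scatter), so the change from 4-methylpyridin-2-yl to pyridin-2-yl shows no readable gain on this core. The same kind of change therefore does not carry over at one size between the two cores: the same change on two cores in this assay, a number 22.9 percentage points higher (beyond the scatter) from compound 3 to compound 1 and a number 4.4 percentage points higher (within the scatter) from compound 2 to compound 4, 18.5 percentage points apart, beyond the scatter of two such steps
These two pairs do not show whether the gap follows the place of the methyl, here opposite the ring nitrogen, or the rest of the core, and they say nothing about any third core.

Open, on these data alone, is how an amine, a methoxy group or a chlorine atom on that aromatic carbon would compare with hydrogen and methyl. Also open, as far as these compounds go, is how a methyl opposite the ring nitrogen would read on the core of compound 1.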